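Sulfonamide nitrogen substituent swap in a PLK2 dihydropteridinone series

A few compounds are considered here, and "the series" means these few. Any claim that something is new, unique, unknown or untested is made for them only; others in the source may bear on it.

Compound 1: `CCC1C(=O)N(C)c2cnc(-n3ccc4cc(C(=O)NC(C)C)ccc43)nc2N1c1ccn(C)n1` gives 125 nM in an assay for inhibition of serine/threonine-protein kinase PLK2 (Homo sapiens), read by FRET and Z'-LYTE, with a stated time of 1 h; on this read-out higher numbers stand for weaker inhibition and lower numbers for stronger inhibition
Compound 2: `CC[C@@H]1C(=O)N(C)c2cnc(Nc3ccc(S(=O)(=O)Nc4ccccc4)cc3)nc2N1C1CCCC1` gives 54.4 nM in this assay

Compound 2 has the lowest of the two numbers measured in this assay, and the nearest is compound 1, whose value sits beyond the scatter above it. Compound 3, `CC[C@@H]1C(=O)N(C)c2cnc(Nc3ccc(S(=O)(=O)NCCO)cc3)nc2N1C1CCCC1`, has not yet been measured in this assay. It differs from compound 2 by 2-hydroxyethyl in place of phenyl on a sulfonamide nitrogen. Among the compounds with values here, no measured pair shows this change, so its effect is unknown. A modest step toward a higher number is expected from compound 2 to compound 3, a 2.0-fold higher number from compound 2 to compound 3 (0.31 log units; beyond the scatter), and compound 3 is estimated at 110 nM with a range of 30 nM to 400 nM.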

Compound 3, half-maximal inhibitory concentration: 7.86 nM
For compound 3 the middle estimate is 14-fold (1.15 log units) above the measured one; the measured number lies below the stated range.
By their numbers in this assay, from the lowest: compound 3; then compound 2; then compound 1.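

In this assay, 2-hydroxyethyl in place of phenyl on the sulfonamide nitrogen gives a 6.9-fold lower number from compound 2 to compound 3 (0.84 log units; beyond the scatter) with no other change to the structure. This position therefore needs no aromatic ring for a low number, and here a smaller chain without a ring gives stronger inhibition. No evidence at hand accounts for this gain.

From the compounds shown here alone, whether the step comes from losing the phenyl or from gaining the hydroxyl remains open, as this one change does both. Plain ethyl, 2-methoxyethyl, 2-aminoethyl and the longer 3-hydroxypropyl on this nitrogen would begin to separate these possibilities.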